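This account rests on a few compounds, and the source may have more. Where it says the series, first, only, none or still open, it means among the compounds named here.

Compound 1 `COC(=O)c1cc(-c2cccc(NC(=O)c3ccc(/C=C/C(=O)c4cccc(Cl)c4)cc3)c2)on1` was examined in an ADME assay on Vero cells (Chlorocebus sabaeus) for cytotoxicity, read by MTT assay, with a stated time of 72 h; on this read-out lower numbers stand for higher toxicity in this test and higher numbers for lower toxicity in this test. There compound 1 gives only a limit, > 2.5 ug/mL, and not a number. Compound 2 `COC(=O)c1cc(-c2cccc(NC(=O)c3ccc(/C=C/C(=O)c4cccc(C(F)(F)F)c4)cc3)c2)on1` likewise returns a limit in this assay, > 20 ug/mL. Compound 3 `CCOc1ccc(C(=O)/C=C/c2ccc(C(=O)Nc3cccc(-c4cc(C(=O)OC)no4)c3)cc2)cc1` gives > 40 ug/mL in this assay, again a limit. The step that the two limits leave unreadable from compound 1 to compound 2 and the step that the two limits leave unreadable from compound 1 to compound 3 thus cannot be read, and compound 1 stands at a limit among limits. Compound 4 `COC(=O)c1cc(-c2cccc(NC(=O)c3ccc(/C=C/C(=O)c4ccc(OC)cc4)cc3)c2)on1` differs from compound 1 in that (4-methoxyphenyl in place of 3-chlorophenyl on a carbonyl carbon); the 3-chlorophenyl leaves and a 4-methoxyphenyl enters on the carbonyl carbon. The measured steps from compound 1 bear on this change but give no size, so no step beyond the scatter is expected in this assay, and another limit seems likely. Compound 4 is estimated at 40 ug/mL, within 10 ug/mL to 100 ug/mL, which means an expected step that the limit leaves unreadable from compound 1 to compound 4.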

Compound 4, half-maximal cytotoxic concentration: > 10 ug/mL
Compound 4 was reported as a limit; the forecaster's own chance of this, stated with the estimate: 80%; the middle value does not contradict the limit.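

In this assay, among the compounds shown here, compounds 1, 2, 3 and 4 all give only limits, so no step among them can be read. The compounds shown leave open where each true value lies and whether changing the group on the carbonyl carbon shifts it.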